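The compounds below may be only part of what the source reports. "The series", "measured", "known", "first", "only" and "open" are said of these compounds alone.

Compound 1 `CC1(Cc2ccc(C(F)(F)F)cc2)CC(S(=O)(=O)c2ccc(F)cc2)=C(c2ccc(/C(N)=N/O)cc2)O1`: 103000 nM
Compound 2 `CC1(Cc2cccc(C(F)(F)F)c2)CC(S(=O)(=O)c2ccc(F)cc2)=C(c2ccc(/C(N)=N/O)cc2)O1`: 49800 nM
Compound 3 `CC1(Cc2ccc([N+](=O)[O-])cc2)CC(S(=O)(=O)c2ccc(F)cc2)=C(c2ccc(/C(N)=N/O)cc2)O1`: 97400 nM

In an ADME assay on cells (Peritoneal macrophage, Mus musculus, strain Balb/c) for cytotoxicity, read by resazurin assay, with a stated time of 72 h (a higher number here means that more compound is tolerated, a lower number that less compound is tolerated), compound 3 gives 97400 nM, which lies within the scatter of both other compounds: the data show a 1.1-fold lower number from compound 1 to compound 3 (0.02 log units; within the scatter) and a 2.0-fold higher number from compound 2 to compound 3 (0.29 log units; within the scatter). Compound 4 `Cc1cccc(CC2(C)CC(S(=O)(=O)c3ccc(F)cc3)=C(c3ccc(/C(N)=N/O)cc3)O2)c1` is still unmeasured. Its difference is 3-methylphenyl in place of 4-nitrophenyl on a saturated chain carbon bound to a saturated ring carbon. For the measured compounds named here, no measured compound carries 3-methylphenyl. The closest guide is a 2.1-fold lower number from compound 1 to compound 2 (0.32 log units; beyond the scatter), a modest step and the only one beyond the scatter, leading to 3-(trifluoromethyl)phenyl. A small downward change is therefore expected, with a 1.5-fold lower number from compound 3 to compound 4 (0.18 log units; within the scatter) as the estimated step. The expected value for compound 4 is 65000 nM, with an estimated range from 30000 nM to 125000 nM.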

Compound 4, half-maximal cytotoxic concentration: 112000 nM
Estimate against measurement, compound 4: 1.7-fold (0.24 log units) below; low and high end bracket the measured number.
By their numbers in this assay, from the lowest: compounds 2, 3, 1 and 4 (each within the scatter of the next, the first and the last beyond it).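

In this assay, 3-methylphenyl on this saturated chain carbon stays level with the groups it replaces, with a 1.1-fold higher number from compound 3 to compound 4 (0.06 log units; within the scatter) and a 1.1-fold higher number from compound 1 to compound 4 (0.04 log units; within the scatter). A substituent at the 3-position of the phenyl ring therefore does not by itself go with the lower number of compound 2, since exchanging trifluoromethyl for methyl gives a 2.2-fold higher number from compound 2 to compound 4 (0.35 log units; beyond the scatter). No measurement at hand explains this difference. On these data alone, whether an amine or a carboxylic acid on this phenyl ring, or a longer chain in place of the benzyl link, would keep the number at this level remains open.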